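A few compounds are considered here, and "the series" means these few. Any claim that something is new, unique, unknown or untested is made for them only; others in the source may bear on it.

Measured so far in an assay on HEK293 cells for agonist activity at transient receptor potential cation channel subfamily M member 8 (Homo sapiens), read by fluorescence and calcium flux, with a stated time of 15 min; on this read-out higher numbers stand for an effect only at larger amounts of compound and lower numbers for an effect already at smaller amounts:
compound 1 `CCN(Cc1cccs1)C(=O)COc1ccc(C(F)(F)F)cc1` gives 236 nM
compound 2 `CCC(C)N(Cc1cccs1)C(=O)COc1ccc(C)cc1` gives 2000 nM
compound 3 `Cc1ccc(/C=C/C(=O)N(Cc2cccs2)c2ccn[nH]2)cc1` gives 0.004 nM

Compound 2 gives the highest number of the three. Its nearest neighbour on the scale is compound 1, whose number is lower by a margin beyond the scatter; compound 3 sits far lower still, and the gap between compound 2 and compound 3 is very wide. Compound 1 and compound 2 share the core of compound 2 but differ both on the amide-type nitrogen and elsewhere in the molecule; compound 3 is built differently. Among the compounds with values here, no step between measured compounds that differ in one place has been worked out, so the weight of any single change on the core of compound 2 is not known from what is here.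

The next compound, compound 4 `Cc1ccc(OCC(=O)N(O)Cc2cccs2)cc1`, differs from compound 2 in one place: hydroxy in place of sec-butyl on an amide-type nitrogen. Nothing measured bears on a hydroxy at this nitrogen, so the expectation rests only on where compound 2 stands. Compound 2 already sits at the weak end, and nothing shown argues for a large move away from it. The expected step is a 1.8-fold higher number from compound 2 to compound 4 (0.24 log units; within the scatter), small, toward higher numbers, and possibly not beyond the scatter. The estimate for compound 4 is 3500 nM, with a range from 700 nM to 18000 nM.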

Compound 4, half-maximal effective concentration: 8000 nM
Compound 4: the middle estimate sits 2.3-fold (0.36 log units) below what was measured, within the range that was stated.
By their numbers in this assay, from the lowest: compound 3; then compound 1; then compound 2; then compound 4.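

In this assay, within the data shown here, the exchange of sec-butyl for hydroxy on the amide-type nitrogen gives a 4.0-fold higher number from compound 2 to compound 4 (0.60 log units; beyond the scatter), the first step that isolates a single place. It shows that the group on this nitrogen does influence the reading on the core of compound 2, though the move is modest and runs toward an effect only at larger amounts of compound. No measurement shown bears on what lies behind this step.

One step cannot separate what follows from the loss of sec-butyl from what follows from the arrival of hydroxy, since both happen in the same change, and a methoxy or an unbranched n-butyl on the same nitrogen would be needed to pull the two apart. The compounds shown also leave open whether the step keeps its direction and size on other cores, such as the core of compound 1, where the same hydroxy in place of the group on the amide-type nitrogen would give a second reading of this change.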